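The source may report more compounds than this note shows. Statements on the series, on what has been measured and on what is new or still open speak of the compounds shown alone.

Compound 2 `O=C(CCc1ccc(C2CCCCC2)cc1)N1CCCC1` — 500 nM
Compound 1 `O=C(CCc1ccc(-c2ccc(Cl)cc2)cc1)N1CCCC1` — 48600 nM

Among the measured compounds shown here, in an assay on HEK293 cells for inhibition of N-acylethanolamine-hydrolyzing acid amidase (Rattus norvegicus), read by LC-MS, with a stated time of 30 min (on this read-out higher numbers stand for weaker inhibition and lower numbers for stronger inhibition), compound 2 gives 500 nM, the lowest of the two numbers measured so far. For the measured compounds named here, its nearest neighbour is compound 1, which in this assay gives 48600 nM; the single measured step, a 97-fold lower number from compound 1 to compound 2 (1.99 log units; beyond the scatter), came with cyclohexyl in place of 4-chlorophenyl on an aromatic carbon of the shared core.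

Compound 3 `O=C(CCc1ccc(OC2CCCCC2)cc1)N1CCCC1` has not yet been measured. It differs from compound 2 by cyclohexyloxy in place of cyclohexyl on an aromatic carbon. Going by the values given here, no measured step alters this group in the same way. Among the compounds with values here, the one known step, a 97-fold lower number from compound 1 to compound 2 (1.99 log units; beyond the scatter), shows that exchanging the group on this aromatic carbon can move the number a great deal, but it sets one ring against another rather than the same ring against that ring joined through oxygen. Within the data shown here, the data thus give no direction for the step from compound 2 to compound 3, and only a modest change in this assay, in either direction, is expected. Compound 3 is estimated at 800 nM, within a range of 150 nM to 5000 nM. Compound 3 is accordingly expected to show a step of a 1.6-fold higher number from compound 2 to compound 3 (0.20 log units; within the scatter).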

Compound 3, half-maximal inhibitory concentration: 700 nM
Beside the measured number, compound 3's estimate is 1.1-fold (0.06 log units) above it; the range from low to high includes it.
By their numbers in this assay, from the lowest: compounds 2 and 3 (each within the scatter of the next); then compound 1.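

In this assay, putting an oxygen link between the aromatic carbon and the six-membered carbon ring leaves the number within the scatter, as a 1.4-fold higher number from compound 2 to compound 3 (0.15 log units; within the scatter) shows; the result therefore shows that, at this one position, cyclohexyloxy and cyclohexyl cannot be told apart, even though cyclohexyloxy brings one more heavy atom and a hydrogen-bond acceptor. The large gap seen earlier with 4-chlorophenyl also holds for the linked ring, with a 69-fold lower number from compound 1 to compound 3 (1.84 log units; beyond the scatter), so among these three compounds both groups carrying the non-aromatic ring give far lower numbers than 4-chlorophenyl, and none of the three goes against this. Nothing available here accounts for these numbers or for the lack of a measurable effect of the oxygen.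

The compounds shown leave open whether a sulfur atom, an amine nitrogen or a longer chain would serve as the link as well as the oxygen does. They also leave open whether the large gap depends on the chlorine or on the aromatic ring itself, a question that an unsubstituted phenyl at this position would address.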